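The source may report more compounds than this note shows. Statements on the series, on what has been measured and on what is new or still open speak of the compounds shown alone.

Measured compounds:
compound 1, `O=C(N/N=C/c1ccccc1O)c1cc(-c2ccccc2)nn1Cc1ccc(Cl)nc1` — 440 nM
compound 2, `O=C(N/N=C/c1ccccc1O)c1cc(-c2ccc(Cl)cc2)nn1Cc1ccc(Cl)nc1` — 500 nM
compound 3, `COc1ccc(/C=N/NC(=O)c2cc(-c3ccc(Cl)cc3)nn2Cc2ccc(Cl)nc2)cc1` — "not determined" (no result reported)

These compounds were tested in a physicochemical assay on A549 cells for solubility, read by microscopy, with a stated time of 24 h; a lower number here means a stronger inhibitor, a higher number a weaker inhibitor. Only two of them have a number. Compound 2 is one of the two; the other is compound 1, and the step of a 1.1-fold higher number from compound 1 to compound 2 (0.06 log units; within the scatter) lies within the scatter, so the two cannot be set apart. Compound 3 carries a methoxy group on a different ring and has no result, so it offers no number to compare.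

Compound 4, `COc1ccc(-c2cc(C(=O)N/N=C/c3ccccc3O)n(Cc3ccc(Cl)nc3)n2)cc1`, differs from compound 2 in one place: methoxy in place of chloro on an aromatic carbon. Among the compounds with values here, the only measured step at that same position is the one from compound 1 to compound 2, where a chloro group replaced a hydrogen and the number barely moved. Within the data shown here, no measured pair shows the exchange of chloro for methoxy directly. Among the measured compounds shown here, with the one step at this position lying within the scatter, and nothing else to go on, the expectation is a step of no real size in either direction in this assay. Compound 4 is therefore estimated at 500 nM, with a range from 250 nM to 1000 nM, an expected step of no change at the digits printed from compound 2 to compound 4 (within the scatter).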

Compound 4, half-maximal inhibitory concentration: 570 nM
Beside the measured number, compound 4's estimate is 1.1-fold (0.06 log units) below it; low and high end bracket the measured number.
By their numbers in this assay, from the lowest: compounds 1, 2 and 4 (each within the scatter of the next).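

In this assay, within the data shown here, the earlier compounds offered only hydrogen and chloro at this place on the six-membered aromatic ring, and compound 4 adds methoxy, a group with an oxygen and a hydrogen-bond acceptor that chloro lacks. The exchange of chloro for methoxy gives a 1.1-fold higher number from compound 2 to compound 4 (0.06 log units; within the scatter) and the exchange of hydrogen for methoxy gives a 1.3-fold higher number from compound 1 to compound 4 (0.11 log units; within the scatter), so hydrogen, chloro and methoxy cannot be set apart here, and this holds for these three compounds only. Nothing measured alongside these numbers offers an explanation for this result.

The compounds shown leave open whether a group of another kind at this place, such as an amine, a carboxylic acid or a longer chain, would give a step beyond the scatter. Steps to compound 3 cannot be read, as it has no result, so the methoxy group on its other ring remains untested by any number here.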